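Replacing Trifluoromethylphenyl with Methoxyphenyl in a Pyrazoline Series

The source may report more compounds than this note shows. Statements on the series, on what has been measured and on what is new or still open speak of the compounds shown alone.

Of the compounds shown here, two sharing one core have been measured. Compound 1 `S=C(Nc1ccccc1)N1N=C(c2ccccc2)CC1c1ccc2c(c1)OCCO2` gives 3180 nM in a functional assay on WM 266-4 cells (Homo sapiens) for antiproliferative activity, read by MTT assay, with a stated time of 48 h; on this read-out higher numbers stand for weaker inhibition of growth and lower numbers for stronger inhibition of growth. Compound 2 `FC(F)(F)c1ccc(C2=NN(C(=S)Nc3ccccc3)C(c3ccc4c(c3)OCCO4)C2)cc1` gives 52400 nM in this assay, the higher of the two numbers, so compound 2 is the weaker grower inhibitor of the pair. Among the compounds with values here, the single measured step, a 16-fold higher number from compound 1 to compound 2 (1.22 log units; beyond the scatter), describes trifluoromethyl in place of hydrogen on an aromatic carbon.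

Compound 3 `COc1cccc(C2=NN(C(=S)Nc3ccccc3)C(c3ccc4c(c3)OCCO4)C2)c1` has not yet been measured. It differs from compound 2 by 3-methoxyphenyl in place of 4-(trifluoromethyl)phenyl on a carbon with a double bond to nitrogen. Within the data shown here, no measured step covers this exact change. Among the measured compounds shown here, the only step available, a 16-fold higher number from compound 1 to compound 2 (1.22 log units; beyond the scatter), bears on it indirectly: it shows that a ring without trifluoromethyl, in compound 1, gave a markedly lower number than the ring with it, in compound 2. From the compounds shown here alone, since compound 3 also loses the trifluoromethyl, a step downward in this assay is expected, though how far the methoxy group itself shifts the number is unknown, so the estimate is placed between the two measured values. Compound 3 is expected to give 9000 nM, within 2500 nM to 32000 nM, meaning an estimated 5.8-fold lower number from compound 2 to compound 3 (0.77 log units; beyond the scatter).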

Compound 3, concentration for 50% growth inhibition: 1380 nM
For compound 3 the middle estimate is 6.5-fold (0.81 log units) above the measured one, and the stated range ends above it.
By their numbers in this assay, from the lowest: compound 3; then compound 1; then compound 2.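

In this assay the group on the carbon with a double bond to nitrogen proves to be a strong lever, since 3-methoxyphenyl in place of 4-(trifluoromethyl)phenyl gives a 38-fold lower number from compound 2 to compound 3 (1.58 log units; beyond the scatter) and this is the largest of the three steps in the set. Within the data shown here, the earlier compounds showed only that adding a group to this phenyl ring could weaken growth inhibition, as trifluoromethyl did with a 16-fold higher number from compound 1 to compound 2 (1.22 log units; beyond the scatter) in that comparison. Methoxy in place of hydrogen on an aromatic carbon goes the other way, with a 2.3-fold lower number from compound 1 to compound 3 (0.36 log units; beyond the scatter) as a modest step that is still beyond the scatter, so a group on this ring does not always raise the number. No measurement shown gives a reason for these steps.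

From the compounds shown here alone, it remains open whether the large gap comes from the group itself or from its ring position, since the names 4-(trifluoromethyl)phenyl and 3-methoxyphenyl show that both change at once. Going by these compounds, how a hydroxy group, an amine or a longer ethoxy chain on this ring would read also remains open.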